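Swapping fluorines for hydroxyls on the hydrazone aryl group

A few compounds are considered here, and "the series" means these few. Any claim that something is new, unique, unknown or untested is made for them only; others in the source may bear on it.

Three compounds sharing one core have been measured in a functional assay on NCI-H460 cells (Homo sapiens) for cytotoxicity, read by MTT assay, with a stated time of 72 h; on this read-out higher numbers stand for weaker inhibition and lower numbers for stronger inhibition:
Compound 1, `CN(C)CCn1cnnc1-c1cc(Oc2ccc(NC(=O)N/N=C/c3c[nH]c4ccccc34)cc2F)ccn1`, gives 1630 nM.
Compound 2, `CN(C)CCn1cnnc1-c1cc(Oc2ccc(NC(=O)N/N=C/c3ccccc3)cc2F)ccn1`, gives 1780 nM.
Compound 3, `CN(C)CCn1cnnc1-c1cc(Oc2ccc(NC(=O)N/N=C/c3ccc(F)cc3F)cc2F)ccn1`, gives 1930 nM.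

In this assay compound 3 has the highest of the three numbers, but its neighbours are close: a 1.1-fold higher number from compound 2 to compound 3 (0.04 log units; within the scatter), and a 1.2-fold higher number from compound 1 to compound 3 (0.07 log units; within the scatter). Both of these steps, and also a 1.1-fold higher number from compound 1 to compound 2 (0.04 log units; within the scatter), lie within the usual scatter, so on the data shown the three compounds cannot be told apart. All three differ only in the aryl group attached to the carbon with a double bond to nitrogen, and none of those exchanges moved the read-out.

Compound 4, `CN(C)CCn1cnnc1-c1cc(Oc2ccc(NC(=O)N/N=C/c3ccc(O)cc3O)cc2F)ccn1`, is the next point in the same series. The change from compound 3 is 2,4-dihydroxyphenyl in place of 2,4-difluorophenyl on a carbon with a double bond to nitrogen. Going by the values given here, the three measured steps all concern this same aryl group and were all small, so the relevant precedent is that exchanges here leave the read-out in this assay essentially unchanged; there is, however, no measured example in which hydrogen-bond donors enter at this position.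

For compound 4 in this assay the expected result is therefore 2000 nM, with a range of 900 nM to 4500 nM. This estimate means an expected step of a 1.0-fold higher number from compound 3 to compound 4 (0.02 log units; within the scatter), a change no larger than the scatter.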

Compound 4, half-maximal inhibitory concentration: 11300 nM
Compound 4: the middle estimate sits 5.7-fold (0.75 log units) below what was measured; measured number above the stated range.
By their numbers in this assay, from the lowest: compounds 1, 2 and 3 (each within the scatter of the next); then compound 4.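

Going by these compounds alone, this position is not as tolerant as the earlier compounds suggested: in this assay the 2,4-dihydroxyphenyl group gives a 5.9-fold higher number from compound 3 to compound 4 (0.77 log units; beyond the scatter), along with a 6.3-fold higher number from compound 2 to compound 4 (0.80 log units; beyond the scatter) and a 6.9-fold higher number from compound 1 to compound 4 (0.84 log units; beyond the scatter), all beyond the scatter and all towards weaker inhibition. The exchange from compound 3 is especially informative. The leaving and entering groups have the same count of heavy atoms and the same carbon ring, while the two fluorines give way to two hydroxyls, and the count of hydrogen-bond donors and acceptors goes up from none to two each. Nothing measured here accounts for the weaker inhibition of compound 4.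

Going by these compounds, it remains open whether both hydroxyls are needed for this loss, or whether one is enough, and a phenyl ring with a single hydroxyl would test that, while methoxy groups in place of the hydroxyls would test whether the hydroxyl hydrogens matter. Within the data shown here, it is also unclear how this position would respond to other groups on the ring, such as an amine or a carboxylic acid, so the single change seen here cannot yet be read as a general rule.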